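The source may report more compounds than this note shows. Statements on the series, on what has been measured and on what is new or still open speak of the compounds shown alone.

Measured in an assay on Sf21 cells for inhibition of high affinity nerve growth factor receptor (Homo sapiens), read by HTRF, with a stated time of 30 min, in the presence of a further agent that is not named here; a higher number here means a weaker inhibitor, a lower number a stronger inhibitor:
compound 1 `CC1(C)c2[nH]nc(NC(=O)c3ccccc3)c2CN1Cc1ccccc1F`, 450 nM
compound 2 `CC1(C)c2[nH]nc(NC(=O)c3ccccc3)c2CN1Cc1ccc(F)cc1`, 1180 nM
compound 3 `CC1(C)c2[nH]nc(NC(=O)c3ccccc3)c2CN1Cc1ccc(F)cc1F`, 2320 nM

Compound 3 holds the highest of the three numbers; its nearest neighbour is compound 2, with a 2.0-fold higher number from compound 2 to compound 3 (0.29 log units; within the scatter), and its furthest is compound 1, with a 5.2-fold higher number from compound 1 to compound 3 (0.71 log units; beyond the scatter). Compound 4 `CC1(C)c2[nH]nc(NC(=O)c3ccccc3)c2CN1Cc1cc(F)c(F)c(F)c1` differs from compound 3 by 3,4,5-trifluorophenyl in place of 2,4-difluorophenyl on a saturated chain carbon bound to an amine nitrogen in a ring. Among the measured compounds shown here, no measured step swaps one fluorinated phenyl for another in this way; the steps that bear on it are a 2.6-fold higher number from compound 1 to compound 2 (0.42 log units; beyond the scatter) and a 5.2-fold higher number from compound 1 to compound 3 (0.71 log units; beyond the scatter), both beyond the scatter, and a 2.0-fold higher number from compound 2 to compound 3 (0.29 log units; within the scatter). Each addition or relocation of fluorine so far has given a higher or equal number, so a modest further rise in this assay is expected. The expected step is a 1.4-fold higher number from compound 3 to compound 4 (0.14 log units; within the scatter). Compound 4 is estimated at 3200 nM, range 1200 nM to 8500 nM.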

Compound 4, half-maximal inhibitory concentration: 6960 nM
For compound 4 the middle estimate is 2.2-fold (0.34 log units) below the measured one; measured number inside the range.
By their numbers in this assay, from the lowest: compound 1; then compounds 2 and 3 (each within the scatter of the next); then compound 4.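

In this assay the 3,4,5-trifluorophenyl group, on a saturated chain carbon bound to an amine nitrogen in a ring, gives a 3.0-fold higher number from compound 3 to compound 4 (0.48 log units; beyond the scatter) and a 5.9-fold higher number from compound 2 to compound 4 (0.77 log units; beyond the scatter) and a 15-fold higher number from compound 1 to compound 4 (1.19 log units; beyond the scatter) in this series. Compound 2 and compound 3 stand within the scatter of each other, whereas compound 4 is separated from both. Fluorine placement on this phenyl alone therefore spans a large range, with compound 1 the lowest.

Going by these compounds, how a chloro or methoxy group would behave at this position remains open. Nothing shown explains these steps.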